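Aryl Swap on a Sulfonamide Among Three Weak Binders

A few compounds are considered here, and "the series" means these few. Any claim that something is new, unique, unknown or untested is made for them only; others in the source may bear on it.

Three compounds have been measured in an assay on cells for inhibition of HSP60/HSP10 (Homo sapiens), with a stated time of 60 min; a higher number here means a weaker inhibitor, a lower number a stronger inhibitor:

Compound 1, `N#Cc1ccc(S(=O)(=O)Nc2ccc(-c3nc4cc(NS(=O)(=O)c5ccc(C#N)cc5)ccc4o3)cc2)cc1`: 49000 nM
Compound 2, `O=S(=O)(Nc1ccc2oc(-c3ccccc3)nc2c1)c1ccccc1O`: 85000 nM
Compound 3, `O=S(=O)(Nc1ccc(-c2nc3ccccc3o2)cc1)c1cccc(Cl)c1`: 54000 nM

All three numbers are high, so every one of these compounds is only a weak inhibitor. Compound 3 sits second highest of the three. Its closest neighbour is compound 1, and the gap between them lies within the usual scatter of repeated measurements. Compound 2 is the furthest from compound 3, yet even that gap stays within the scatter, so the three compounds cannot be ranked against each other on this evidence.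

For the measured compounds named here, none of the measured compounds differ from one another in a single place, so no measured step gives a yardstick for what a small change does here.

Compound 4, `Cc1ccc(S(=O)(=O)Nc2ccc(-c3nc4ccccc4o3)cc2)cc1`, differs from compound 3 in one place: 4-methylphenyl in place of 3-chlorophenyl on a sulfonyl sulfur. Because every measured value clusters near 54000 nM for compound 3, the expectation is that this exchange moves the number by no more than the scatter, and the step of a 1.1-fold higher number from compound 3 to compound 4 (0.05 log units; within the scatter) is estimated to be small in either direction. Compound 4 is therefore expected to give about 60000 nM, with a range from 25000 nM to 150000 nM.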

Compound 4, half-maximal inhibitory concentration: > 100000 nM
Compound 4 gave a limit, no number; the forecaster's own chance of this, stated with the estimate: 20%; middle value at least 1.6-fold (0.22 log units) away from the limit.
By their numbers in this assay, from the lowest: compounds 1, 3 and 2 (each within the scatter of the next). At a limit, above all of these: compound 4.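

For the compounds shown here, exchanging 3-chlorophenyl for 4-methylphenyl on a sulfonyl sulfur gives the first single-place step in this assay, and it is an at least 1.8-fold higher number from compound 3 to compound 4 (0.26 log units; that floor lies within the scatter). Compound 4 gives > 100000 nM, which is a limit of the assay and not a number. Only a floor for the step is known, so its real size stays open, and compound 4 is the one compound shown at the limit: the limit of > 100000 nM in this assay, at which 1 of the 4 values shown sits.

The compounds shown leave open whether the chlorine, the methyl or the place of each group on the ring matters, a question that 4-chlorophenyl or 3-methylphenyl on the same sulfonyl sulfur would help to separate. They also leave open how the number would respond to an amine or a carboxylic acid on that ring.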